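The source may hold more compounds than are shown below. What is called first, only, known or untested is meant among the compounds shown, and "the series" means these compounds.

Compound 1 `CNC(=O)c1cc(-c2ccc(F)cc2F)ccc1OC(C)=O` is the point of reference. In a functional assay on the whole organism (Ear) for inhibition, with Mus musculus as the target, at a dose of 40 mg/kg by the oral route (on this read-out higher numbers stand for more inhibition at the one dose given (going by the name of the read-out) and lower numbers for less inhibition), compound 1 gives 48.8%. Compound 2 `CC(=O)Oc1ccc(-c2ccc(F)cc2F)cc1C(=O)Nc1ccccc1` differs from it by phenyl in place of methyl on an amide-type nitrogen, and in this assay compound 2 gives 23.2%, so that this change brings a number 25.6 percentage points lower from compound 1 to compound 2 (beyond the scatter). Compound 3 `CNC(=O)c1cc(-c2ccc(F)cc2F)ccc1OC(=O)c1ccccc1` differs from compound 1 in another place, by phenyl in place of methyl on a carbonyl carbon; in this assay compound 3 gives 68.9%, a step of a number 20.1 percentage points higher from compound 1 to compound 3 (beyond the scatter). Among the three measured compounds compound 3 stands highest, with compound 1 nearest to it and compound 2 furthest away.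

Compound 4 `O=C(Oc1ccc(-c2ccc(F)cc2F)cc1C(=O)Nc1ccccc1)c1ccccc1` has not been measured. It differs from compound 3 by phenyl in place of methyl on an amide-type nitrogen. For the measured compounds named here, this is the same change as the one made from compound 1 to compound 2, where it gave a number 25.6 percentage points lower from compound 1 to compound 2 (beyond the scatter); the place is described in the same words for both pairs, so the change is the same. The two cores differ from each other by phenyl in place of methyl on a carbonyl carbon. The change occurs twice among the four compounds and has been measured once. Going by the values given here, for compound 4 the expected step is a number 24.9 percentage points lower from compound 3 to compound 4 (beyond the scatter), which rests on that single measured instance because a number 25.6 percentage points lower from compound 1 to compound 2 (beyond the scatter) is the only guide available. Compound 4 is therefore estimated at 44% in this assay. The expected range for compound 4 runs from 25% to 62%. Among the compounds with values here, the width of that range reflects that only one instance of the change has been measured.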

Compound 4, a percentage reported as inhibition, in the whole organism at one dose (the size of the read-out at that dose, not a potency): 19.8%
The estimate for compound 4 lay 24.2 percentage points above the measured number; the measured number lies below the stated range.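

In this assay phenyl in place of methyl on the amide-type nitrogen lowers the number on the core of compound 3 as it did on the core of compound 1, so the direction carries over, but the new step is a number 49.1 percentage points lower from compound 3 to compound 4 (beyond the scatter) and its size does not carry over: the same change on two cores in this assay, a number 25.6 percentage points lower (beyond the scatter) from compound 1 to compound 2 and a number 49.1 percentage points lower (beyond the scatter) from compound 3 to compound 4, 23.5 percentage points apart, beyond the scatter of two such steps. The second change, phenyl in place of methyl on a carbonyl carbon, carries over less well still, since it gives a number 3.4 percentage points lower from compound 2 to compound 4 (within the scatter) on the core that holds the phenylcarbamoyl group and so loses the rise seen with the methylcarbamoyl group: the same change on two cores in this assay, a number 20.1 percentage points higher (beyond the scatter) from compound 1 to compound 3 and a number 3.4 percentage points lower (within the scatter) from compound 2 to compound 4, 23.5 percentage points apart, beyond the scatter of two such steps. Within these four compounds the two changes therefore do not act independently of each other, but with a single pair of steps for each change this shows neither why they interact nor how either change would behave on any other core.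

The compounds shown leave open whether the steep drop belongs to phenyl itself or would also appear with ethyl, benzyl or a longer chain on the amide-type nitrogen. They also leave open whether an amine or a carboxylic acid on the phenyl ring of the carbonyl side would keep the higher number of compound 3.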